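This account rests on a few compounds, and the source may have more. Where it says the series, first, only, none or still open, it means among the compounds named here.

Compound 1 `Cc1cc(C)c(NC(=O)N(Cc2ccc(N3CCN(C)CC3)cc2)C2CCCCCC2)c(C)c1` is the reference point of this set. In a functional assay on a cell-free system (plasma) with sterol O-acyltransferase, Soat (Rattus norvegicus) as the target (on this read-out higher numbers stand for an effect only at larger amounts of compound and lower numbers for an effect already at smaller amounts), compound 1 returns only a limit, > 1 mg/kg, which is the limit of > 1 mg/kg in this assay, at which 1 of the 3 values shown sits. Compound 2 `COc1cccc(CN(Cc2cccc(-c3cc[nH]n3)c2)C(=O)Nc2c(SC)cc(C)nc2SC)c1` also returns only a limit in this assay, namely > 0.1 mg/kg. Compound 3 `CSc1cc(C)nc(SC)c1NC(=O)N(Cc1ccccc1)Cc1cccc(-c2cnn(C)c2)c1` likewise gives only a limit, > 0.1 mg/kg. Two of the three values therefore sit at the limit of > 0.1 mg/kg in this assay, at which 2 of the 3 values shown sit. Among the measured compounds shown here, compound 1 thus stands at a limit with no number of its own, and no step between measured compounds is available. Compound 4 `Cc1cc(C)c(NC(=O)N(Cc2ccc(-n3cccn3)cc2)C2CCCCCC2)c(C)c1` differs from compound 1 by 1H-pyrazol-1-yl in place of 4-methylpiperazin-1-yl on an aromatic carbon. Without a measured step, no shift beyond the usual scatter is expected in this assay in either direction. The expected step is a step that the limit leaves unreadable from compound 1 to compound 4. Compound 4 is estimated at 2 mg/kg, expected to lie between 0.5 mg/kg and 8 mg/kg.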

Compound 4, dose for half-maximal effect: > 1 mg/kg
Compound 4 ended at the assay's limit; the forecaster's own chance of this, stated with the estimate: 65%; the middle value lies beyond the limit too.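

Compound 1 and compound 4 both return only a limit in this assay, and the step between them cannot be read: the limit of > 1 mg/kg in this assay, at which 2 of the 4 values shown sit.

Still open, as far as these compounds go, is whether 1H-pyrazol-1-yl in place of 4-methylpiperazin-1-yl shifts the half-maximal dose at all, and in which direction.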